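The source may report more compounds than this note shows. Statements on the series, on what has been measured and on what is new or still open speak of the compounds shown alone.

Compound 2 `COc1ccc(-c2nc3cc(F)ccc3s2)cc1O` gives the lowest of the two numbers recorded so far in a functional assay on MDA-MB-468 cells (Homo sapiens) for antiproliferative activity; on this read-out higher numbers stand for weaker inhibition of growth and lower numbers for stronger inhibition of growth. Compound 1 `COc1ccc(-c2nc3cc(F)ccc3s2)cc1` gives 330 nM in this assay, while compound 2 gives 50 nM. Among the compounds with values here, the single step between them, a 6.6-fold lower number from compound 1 to compound 2 (0.82 log units; beyond the scatter), is the only measured step available.

Compound 3 `COc1ccc(-c2nc3cc(F)ccc3s2)cc1OC` has not yet been measured. It differs from compound 2 as follows: methyl in place of hydrogen on an oxygen on an aromatic ring. Within the data shown here, the one measured step bears on this change indirectly: the hydroxy group brought a 6.6-fold lower number from compound 1 to compound 2 (0.82 log units; beyond the scatter), and compound 3 keeps that oxygen but carries a methyl on it instead of a hydrogen. Whether the gain seen with the hydroxy survives this capping cannot be read from the data; the evidence neither secures nor rules it out.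

The account therefore expects compound 3 to move back toward compound 1, giving a number somewhat higher than compound 2, by a 3.6-fold higher number from compound 2 to compound 3 (0.56 log units; beyond the scatter), though possibly within the scatter. The estimate for compound 3 in this assay is 180 nM, with a range from 60 nM to 550 nM.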

Compound 3, concentration for 50% growth inhibition: < 0.1 nM
Compound 3 gave a limit, no number; the forecaster's own chance of this, stated with the estimate: 3%; at least 1800-fold (3.25 log units) between middle value and limit.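

Compound 3 stands at a limit of this assay, which is not a number: the limit of < 0.1 nM in this assay, at which 1 of the 3 values shown sits.

Putting methyl in place of hydrogen on this oxygen on an aromatic ring gives an at least 500-fold lower number from compound 2 to compound 3 (2.69 log units; beyond the scatter), so the hydrogen of the hydroxy is not required for low numbers in this series, and capping the oxygen takes the read-out further down instead of back toward compound 1. Set against the unsubstituted position of compound 1, the methoxy gives an at least 3300-fold lower number from compound 1 to compound 3 (3.51 log units; beyond the scatter), a far larger change than the hydroxy gave with a 6.6-fold lower number from compound 1 to compound 2 (0.82 log units; beyond the scatter), so the place responds much more strongly to the exact group on the oxygen than the first pair could show.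

With a limit in place of a number, the full size of both new steps stays open, and the compounds shown cannot say how far compound 3 lies past that limit. They also leave open whether the gain is particular to methyl on this oxygen, or whether an ethoxy, a longer alkoxy chain or an amine at the same place would read in a similar way.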